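The source may hold more compounds than are shown below. What is called first, only, known or untested is meant among the compounds shown, and "the series" means these compounds.

Compound 1 `CC(=O)Nc1ccc(S(=O)(=O)NNC(=O)c2cccnc2Nc2ccc(Cl)cc2)cc1` carries a 4-acetamidophenyl on its sulfonyl sulfur. Among the measured compounds shown here, in a functional assay on MCF7 cells (Homo sapiens) for inhibition, tested at 10 uM (on this read-out lower numbers stand for less inhibition and higher numbers for more inhibition at the one concentration tested (going by the name of the read-out)), compound 1 gives 52%, the second highest of the three numbers measured so far. Compound 2 `COc1ccc(Nc2ncccc2C(=O)NNS(=O)(=O)c2ccc(C)cc2)cc1` gives 102% in this assay, a reading beyond the scatter above compound 1, while compound 3 `O=C(NNS(=O)(=O)c1ccc(F)cc1)c1cccnc1Nc1ccc(Cl)cc1Cl` gives 0%, a reading beyond the scatter below compound 1. Compound 4 `O=C(NNS(=O)(=O)c1ccc(Cl)cc1Cl)c1cccnc1Nc1ccc(Cl)cc1` has not yet been measured. It differs from compound 1 in a single place: 2,4-dichlorophenyl in place of 4-acetamidophenyl on a sulfonyl sulfur. For the measured compounds named here, no pair of measured compounds isolates this change on the shared core; compound 3 carries a different group on its sulfonyl sulfur and also differs elsewhere, so it offers no clean comparison, and compound 2 differs in two places as well. With nothing to anchor the direction, the expected step in this assay is a number 14 percentage points lower from compound 1 to compound 4 (beyond the scatter), a modest decrease that may well lie within the scatter. Compound 4 is estimated at 38% in this assay, with a range from 5% to 80%.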

Compound 4, a percentage reported as inhibition, at one concentration (the size of the read-out at that concentration, not a potency): 44%
Compound 4: the middle estimate sits 6 percentage points below what was measured; the measured number falls inside the stated range.
By their numbers in this assay, from the lowest: compound 3; then compounds 4 and 1 (each within the scatter of the next); then compound 2.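

In this assay, among the compounds shown here, putting 2,4-dichlorophenyl in place of 4-acetamidophenyl on a sulfonyl sulfur gives a number 8 percentage points lower from compound 1 to compound 4 (within the scatter), so this is the first clean comparison at this position, and the two compounds cannot be told apart. The group that leaves carries a hydrogen-bond donor and a hydrogen-bond acceptor and the group that enters carries neither, yet in this single pair the swap stays within the scatter. Nothing measured here bears on why the two readings lie so close.

Going by these compounds, whether a phenyl carrying an amine or a carboxylic acid, or a short alkyl chain in place of the ring, would also stay within the scatter at this sulfonyl sulfur remains open. On these data alone, it is also open whether the same swap would behave alike on the core of compound 2.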